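Trifluoromethyl for fluoro on an aryl urea of compound 3

The source may hold more compounds than are shown below. What is called first, only, known or untested is meant among the compounds shown, and "the series" means these compounds.

Measured so far:
compound 1, `CCOC(=O)CNC(=O)N1CC1C#N`: 11000 nM
compound 2, `CCCCNC(=O)N1CC1C#N`: > 12000 nM
compound 3, `N#CC1CN1C(=O)Nc1ccc(F)cc1`: 2700 nM

In a functional assay on MCF7 cells (Homo sapiens) for inhibition (a lower number here means a stronger inhibitor, a higher number a weaker inhibitor), compound 1 gives 11000 nM. For compound 2 the assay reports only a limit, > 12000 nM, not a number (the limit of > 12000 nM in this assay, at which 1 of the 3 values shown sits). Compound 3 gives 2700 nM, the lowest of the two numbers; its gap to compound 1 lies beyond the scatter. Compound 4, `N#CC1CN1C(=O)Nc1ccc(C(F)(F)F)cc1`, carries trifluoromethyl in place of fluoro on an aromatic carbon. Within the data shown here, no measured pair shows this change, so the step is expected to be small: from compound 3 to compound 4 an estimated 1.4-fold lower number from compound 3 to compound 4 (0.13 log units; within the scatter), within or only just beyond the scatter, with either direction possible. Compound 4 is therefore expected near 2000 nM, between 600 nM and 7000 nM.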

Compound 4, half-maximal inhibitory concentration: 1300 nM
Beside the measured number, compound 4's estimate is 1.5-fold (0.19 log units) above it, within the range that was stated.
By their numbers in this assay, from the lowest: compound 4; then compound 3; then compound 1. At a limit, above all of these: compound 2.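

This is the only pair shown that differs in one place. On an aromatic carbon of the six-membered ring, trifluoromethyl in place of fluoro gives, in this assay, a 2.1-fold lower number from compound 3 to compound 4 (0.32 log units; beyond the scatter), so a group of 4 heavy atoms is accepted where 1 stood, and the modest step lies beyond the scatter. No measurement shown accounts for this step. From the compounds shown here alone, a single pair sets no trend, so it remains open whether a methoxy group, an amine or a carboxylic acid on this carbon would give a lower or a higher number.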